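This account rests on a few compounds, and the source may have more. Where it says the series, first, only, none or still open, it means among the compounds named here.

Compounds measured in a functional assay for inhibition, with Homo sapiens as the target; a lower number here means a stronger inhibitor, a higher number a weaker inhibitor:
Compound 1 `CCCc1nc(C)c2c(C)nn(C)c(=O)n12`: compound 1 gives > 48000 nM, a limit of this assay.
Compound 2 `CCCc1ncc2c(C)nnc(O)n12`: compound 2 gives > 48000 nM, likewise a limit.
Compound 3 `CCCc1nc(C)c2c(C)nnc(O)n12`: compound 3 gives 14000 nM.

Compound 2 stands at the limit of this assay; it is one of the two compounds that sit at the limit of > 48000 nM in this assay, at which 2 of the 3 values shown sit, and only compound 3 returns a number. For the measured compounds named here, the single step measured between compounds differing in one place is an at least 3.4-fold lower number from compound 2 to compound 3 (0.53 log units; beyond the scatter), a methyl added on an aromatic carbon of the shared core of compound 2.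

Compound 4 `CCCc1ncc2c(C)nnc(S)n12` differs from compound 2 in another way: sulfanyl in place of hydroxy on an aromatic carbon. Going by the values given here, none of the measured steps touches this group; the only measured step concerns a methyl and gives no guide to swapping hydroxy for sulfanyl. Compound 2 itself gives no number but a limit, so any step from it can only be read as a departure from that limit. With nothing bearing on the change, no step beyond the scatter is expected in this assay for compound 4, and the most likely outcome is that compound 4 again returns only a limit. The estimate for compound 4 is 60000 nM, between 15000 nM and 200000 nM. This estimate is expected to mean a step that the limit leaves unreadable from compound 2 to compound 4.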

Compound 4, half-maximal inhibitory concentration: > 48000 nM
Compound 4 gave a limit, no number; the forecaster's own chance of this, stated with the estimate: 75%; the middle value lies beyond the limit too.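

In this assay compound 4 gives > 48000 nM, a limit and not a number. Compound 2 and compound 4 both stand at a limit, and the step between them, sulfanyl in place of hydroxy, cannot be read: the limit of > 48000 nM in this assay, at which 3 of the 4 values shown sit.

The compounds shown leave open whether this swap changes inhibition at all, including on the core of compound 3, the only compound here that returns a number.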